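A few compounds are considered here, and "the series" means these few. Any claim that something is new, unique, unknown or untested is made for them only; others in the source may bear on it.

Measured in a functional assay on Vero cells (Chlorocebus sabaeus) for cytotoxicity; a lower number here means a stronger inhibitor, a higher number a weaker inhibitor:
- Compound 1 `O=c1ccn([C@@H]2S[C@H](CO)[C@H]2CO)c(=O)[nH]1`: > 100000 nM (a limit)
- Compound 2 `Nc1ncnc2c1ncn2[C@@H]1S[C@H](CO)[C@H]1CO`: > 100000 nM (a limit)

Compound 2 sits at > 100000 nM, which is a limit of the assay and not a number. Among the measured compounds shown here, the only evidence so far is the limit of > 100000 nM in this assay, at which 2 of the 2 values shown sit. Compound 3 `OC[C@H]1[C@H](n2cnc3c(O)ncnc32)S[C@@H]1CO` differs from compound 2 by one change, hydroxy in place of amino on an aromatic carbon. For the measured compounds named here, no measured step is available for this change. In this assay, no change beyond the scatter is expected, in either direction. This expectation rests on compound 2 and its limit of > 100000 nM. The expected step is a number no higher from compound 2 to compound 3 (the limit leaves the size open). Compound 3 is estimated at 100000 nM, within an expected range of 40000 nM to 300000 nM.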

Compound 3, half-maximal inhibitory concentration: > 100000 nM
Compound 3 gave a limit, no number (the forecaster's own chance of this, stated with the estimate: 90%); the middle value sits exactly at the limit.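

No step can be read from compound 2 to compound 3, as both give only a limit in this assay. The compounds shown leave open whether any change to the shared core gives a number in this assay rather than a limit.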